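Swapping Phenethyl for 4-Fluorophenyl on a Sulfur

The source may report more compounds than this note shows. Statements on the series, on what has been measured and on what is new or still open speak of the compounds shown alone.

Compound 1 `Cc1ccc(SCc2ccc(C(=O)Nc3ccccc3N)cc2)cc1` gives 40.5% 
Compound 2 `Nc1ccccc1NC(=O)c1ccc(CSCCc2ccccc2)cc1` gives 44.9% 

Among the measured compounds shown here, both values come from a functional assay on A549 cells (Homo sapiens) for inhibition, read by CCK-8 assay, with a stated time of 72 h, tested at 2 uM (on this read-out lower numbers stand for less inhibition of growth and higher numbers for more inhibition of growth at the one concentration tested), and are the only numbers available so far. Compound 2 has one measured neighbour, and the two stand level within the scatter. For the measured compounds named here, their step reads a number 4.4 percentage points higher from compound 1 to compound 2 (within the scatter) and is the only measured step. Compound 3 `Nc1ccccc1NC(=O)c1ccc(CSc2ccc(F)cc2)cc1` now takes the change 4-fluorophenyl in place of phenethyl on a sulfur on the same sulfur, with 4-fluorophenyl in place of phenethyl. The measured step bears on it. That step concerns the same place. Compound 1, with 4-methylphenyl on that sulfur, gives 40.5%, so no step beyond the scatter is expected in this assay here. The estimated step is a number 2.9 percentage points lower from compound 2 to compound 3 (within the scatter) for this swap. For compound 3 the expected value is 42%, with an estimated range from 30% to 55% in this read-out.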

Compound 3, percent growth inhibition at one concentration: 43.4%
The estimate for compound 3 lay 1.4 percentage points below the measured number; low and high end bracket the measured number.
By their numbers in this assay, from the lowest: compounds 1, 3 and 2 (each within the scatter of the next).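

Placing 4-fluorophenyl instead of phenethyl on the sulfur gives a number 1.5 percentage points lower from compound 2 to compound 3 (within the scatter) in this assay, so a ring held directly on the sulfur and one held through the phenethyl chain stand level here. Fluoro in place of methyl on an aromatic carbon gives a number 2.9 percentage points higher from compound 1 to compound 3 (within the scatter), which adds a second change on this group that shows no step beyond the scatter. No evidence is at hand that would explain why these compounds stand level.

Going by these compounds, it stays open whether an amine or a carboxylic acid on that aromatic ring, or a longer chain on the sulfur, would move the number beyond the scatter. A single concentration also leaves open whether the three compounds would still stand level at other concentrations.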